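The compounds below may be only part of what the source reports. "The series", "measured", "known", "first", "only" and "open" are said of these compounds alone.

The three measured compounds and their values:

Compound 1, `S=C(SCc1nc2cc(Cl)c(Cl)cc2[nH]1)N1CCCCC1`, gives 42800 nM in a functional assay on MCF7 cells (Homo sapiens) for cytotoxicity, read by MTT assay, with a stated time of 24 h; on this read-out higher numbers stand for weaker inhibition and lower numbers for stronger inhibition.
Compound 2, `CCOc1ccccc1N1CCN(C(=S)SCc2nc3cc(C)c(C)cc3[nH]2)CC1`, gives 5580 nM in this assay.
Compound 3, `c1ccc2[nH]c(SCCCN3CCNCC3)nc2c1`, gives 91700 nM in this assay.

Among these three, compound 3 has the highest number, so it is the weakest inhibitor of the set. Its nearest neighbour is compound 1, whose number is lower by a margin beyond the usual scatter, and compound 2 stands furthest away with a much lower number. Compound 2 is also the only one of the three that carries an aromatic group on the ring nitrogen of its six-membered non-aromatic ring with two nitrogens.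

Compound 4, `Clc1cccc(N2CCN(CCCSc3nc4ccccc4[nH]3)CC2)c1`, has not yet been measured. It differs from compound 3 in one place: 3-chlorophenyl in place of hydrogen on an amine nitrogen in a ring. This single change attaches a group of the same general kind that distinguishes compound 2 from the rest, although the rest of compound 2 differs too much from compound 3 for a clean comparison.

Given that compound 2 gives 5580 nM while compound 3 gives 91700 nM, the expected step from compound 3 to compound 4 is a clear drop in the number, estimated at a 4.6-fold lower number from compound 3 to compound 4 (0.66 log units; beyond the scatter). Compound 4 is therefore expected to come in near 20000 nM, within a range of 6000 nM to 60000 nM.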

Compound 4, half-maximal inhibitory concentration: 54600 nM
The estimate for compound 4 lay 2.7-fold (0.44 log units) below the measured number; low and high end bracket the measured number.
By their numbers in this assay, from the lowest: compound 2; then compounds 1, 4 and 3 (each within the scatter of the next, the first and the last beyond it).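

In this assay, for the compounds shown here, putting 3-chlorophenyl in place of hydrogen on an amine nitrogen in a ring gives a 1.7-fold lower number from compound 3 to compound 4 (0.23 log units; within the scatter), the first step in this set that compares two compounds differing in one place. At this position, therefore, a whole six-membered aromatic ring can take the place of a single hydrogen atom without the two compounds being separable in this assay, so this change alone shows no measurable gain in cytotoxicity. Nothing measured here offers an explanation for this result.

The compounds shown leave open whether a different group on this same nitrogen, such as benzyl or acetyl, or a longer chain in place of the present one, would shift the number beyond the scatter. Compound 2, at 5580 nM, differs from compound 4 in more than one place, so which of those differences goes with its lower number remains an open question.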